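This account rests on a few compounds, and the source may have more. Where it says the series, first, only, none or still open, it means among the compounds named here.

Compound 1 `C=C(C)COc1ccc(-c2c(C#N)c(N)nc(SCC(N)=O)c2C#N)cc1`: 4%
Compound 2 `N#Cc1c(N)nc(SCc2cnc[nH]2)c(C#N)c1-c1ccc(OCC2CC2)cc1`: 1%

Both numbers come from an assay on CHO cells for displacement of a labelled ligand from adenosine receptor A3 (Homo sapiens), read by scintillation counting, with a stated time of 120 min, tested at 1 uM; on this read-out higher numbers stand for more inhibition at the one concentration tested (going by the name of the read-out) and lower numbers for less inhibition. Compound 1 gives 4% in this assay, and compound 2 gives 1%, a gap that lies within the usual scatter, so neither compound can be set above the other on these figures. Compound 3 `N#Cc1c(N)nc(SCC(N)=O)c(C#N)c1-c1ccc(OCC2CCC2)cc1` has not been measured. Against compound 1 it differs in one place: cyclobutyl in place of 1-methylethenyl on a saturated chain carbon bound to an oxygen on an aromatic ring. Going by the values given here, no step between measured compounds is available to guide the expectation. The expected step is a number 1 percentage points higher from compound 1 to compound 3 (within the scatter), nothing beyond the scatter. Compound 3 is therefore estimated at 5%, between -5% and 15%.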

Compound 3, a percentage reported as inhibition, at one concentration (the size of the read-out at that concentration, not a potency): 1%
The estimate for compound 3 lay 4 percentage points above the measured number, within the range that was stated.
By their numbers in this assay, from the lowest: compounds 2, 3 and 1 (each within the scatter of the next).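

In this assay, going by these compounds alone, the change from 1-methylethenyl to cyclobutyl, on a saturated chain carbon bound to an oxygen on an aromatic ring, gives a number 3 percentage points lower from compound 1 to compound 3 (within the scatter) and is the first step that can be read at this position. On this one step, the four-membered ring in place of the double bond outside aromatic rings does not separate the two compounds. No measurement shown explains this result. Going by these compounds, whether an amine or a carboxylic acid at this position, or a longer chain, would give a step beyond the scatter remains open.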